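The compounds below may be only part of what the source reports. "The series", "measured", "known", "first", "only" and "open" are said of these compounds alone.

Compound 1 `c1cnc2c(c1)CCC[C@@H]2N(CC1CC1)C[C@H]1Cc2c(cccc2N2CCNCC2)CN1`: in a functional assay on CCRF-CEM cells for agonist activity at C-X-C chemokine receptor type 4 (Homo sapiens), read by calcium flux, with a stated time of 25 min (on this read-out higher numbers stand for an effect only at larger amounts of compound and lower numbers for an effect already at smaller amounts), compound 1 gives only the limit > 30000 nM.
Compound 2 `C[C@@H]1CN(c2cccc3c2C[C@H](CN(C)[C@H]2CCCc4cccnc42)NC3)C[C@H](C)N1`: in this assay compound 2 likewise gives only the limit > 30000 nM.
Compound 3 `CN(C[C@H]1Cc2c(cccc2N2CCN(C3CC3)CC2)CN1)[C@H]1CCCc2cccnc21`: in this assay compound 3 also gives only the limit > 30000 nM.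

Compound 1 thus stands at the limit shared by every measured compound, as the limit of > 30000 nM in this assay, at which 3 of the 3 values shown sit, records; no number separates it from compound 2 or compound 3. Compound 4 `FC1(F)CCC(CN(C[C@H]2Cc3c(cccc3N3CCNCC3)CN2)[C@H]2CCCc3cccnc32)CC1` differs from compound 1 by 4,4-difluorocyclohexyl in place of cyclopropyl on a saturated chain carbon bound to an amine nitrogen. Among the measured compounds shown here, the only measured step in this set, a step that the two limits leave unreadable from compound 2 to compound 3, is unreadable and alters a different part of the shared core; no measured step bears on the present change. With three limits and no readable step, the expectation for compound 4 is that it stays at the limit, and a number no higher from compound 1 to compound 4 (the limit leaves the size open) is expected to be no step beyond the scatter. Compound 4 is therefore estimated at 30000 nM, with a range from 10000 nM to 60000 nM.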

Compound 4, half-maximal effective concentration: > 30000 nM
Compound 4: no number, only a limit; the forecaster's own chance of this, stated with the estimate: 85%; the middle value lies on the limit itself.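

In this assay compound 4 gives only the limit > 30000 nM, and the step from compound 1 to compound 4 cannot be read. The compounds shown leave open how any of them would rank on a measured number.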